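The compounds below may be only part of what the source reports. "The series", "measured", "known", "first", "only" and "open" are said of these compounds alone.

Compound 1, `CNC(=O)/C=C/c1ccncc1-c1ccc2[nH]ccc2c1`: in a functional assay on A549 cells (Homo sapiens) for inhibition, read by sulforhodamine B assay, with a stated time of 72 h (a higher number here means a weaker inhibitor of growth, a lower number a stronger inhibitor of growth), compound 1 gives > 10000 nM, which is a limit of the assay and not a number.
Compound 2, `O=C(O)CCc1ccncc1-c1ccc2ccccc2c1`: in this assay compound 2 gives > 10000 nM, again a limit rather than a number.
Compound 3, `O=C(CCc1ccncc1-c1ccc2ccccc2c1)N1CCOCC1`: in this assay compound 3 gives > 10000 nM, also a limit.

Compound 2 thus stands only at a limit in this assay, and every value shown sits at that same limit (the limit of > 10000 nM in this assay, at which 3 of the 3 values shown sit). Going by the values given here, the one measured step that alters compound 2 is a step that the two limits leave unreadable from compound 2 to compound 3; its size cannot be read because both ends rest on the limit (the limit of > 10000 nM in this assay, at which 3 of the 3 values shown sit).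

Compound 4, `CCOC(=O)/C=C/c1ccncc1-c1ccc2ccccc2c1`, differs from compound 2 at one place: 2-(ethoxycarbonyl)ethenyl in place of 2-carboxyethyl on an aromatic carbon. Among the compounds with values here, no measured step matches this change, and the single step that does touch compound 2 offers no readable size. The expected step that the limit leaves unreadable from compound 2 to compound 4 therefore carries no direction that the data can support. With every shown value at the limit, compound 4 is expected to give 15000 nM, within a range from 4000 nM to 60000 nM, and most probably to be reported once more only as a limit.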

Compound 4, concentration for 50% growth inhibition: 5380 nM
The estimate for compound 4 lay 2.8-fold (0.45 log units) above the measured number, and the stated range covers the measured number.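

In this assay, placing 2-(ethoxycarbonyl)ethenyl in place of 2-carboxyethyl on this aromatic carbon, opposite the ring nitrogen, gives an at least 1.8-fold lower number from compound 2 to compound 4 (0.26 log units; that floor lies within the scatter). Going by these compounds alone, this is the first change at this position that yields a measured number and a step with a readable floor, whereas the earlier step, which replaces hydroxy with morpholin-4-yl, cannot be read. On these data alone, the true size of the new step remains unknown, as the value for compound 2 is only a limit of the assay: the limit of > 10000 nM in this assay, at which 3 of the 4 values shown sit.

The change alters the chain's carbonyl group and adds a double bond at once, so the compounds shown do not separate the ethyl ester from the double bond. They also leave open how a saturated 2-(ethoxycarbonyl)ethyl chain, a 2-carboxyethenyl chain or an amine at this position would read.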